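Amino to Methoxy: One Change, Two Matched Pairs

The compounds below may be only part of what the source reports. "The series", "measured", "known", "first", "only" and "open" are said of these compounds alone.

Compound 1 `Nc1ccccc1/C=C/c1ccccc1O` gives 39 ug/mL in a functional assay on MCF7 cells (Homo sapiens) for inhibition, read by MTT assay, with a stated time of 2 days; on this read-out higher numbers stand for weaker inhibition and lower numbers for stronger inhibition.
Compound 2 `Nc1ccccc1/C=C/c1cccc(O)c1` gives 17 ug/mL in this assay.
Compound 3 `COc1ccccc1/C=C/c1ccccc1O` gives 17.9 ug/mL in this assay.

Compound 3 differs from compound 1 by one change, (methoxy in place of amino on an aromatic carbon), and this gave a 2.2-fold lower number from compound 1 to compound 3 (0.34 log units; beyond the scatter). Compound 2 has the same atoms as compound 1 joined differently; the difference between the two cores is not broken down here. Compound 4 `COc1ccccc1/C=C/c1cccc(O)c1` is not yet measured and differs from compound 2 by the same change, (methoxy in place of amino on an aromatic carbon), at the same place. On the earlier step, the change from compound 2 to compound 4 is expected to give a 1.9-fold lower number from compound 2 to compound 4 (0.28 log units; within the scatter) in this assay, because compound 3 gave a 2.2-fold lower number from compound 1 to compound 3 (0.34 log units; beyond the scatter). Compound 4 is therefore estimated at 9 ug/mL, within 4 ug/mL to 20 ug/mL.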

Compound 4, half-maximal inhibitory concentration: 24.3 ug/mL
The estimate for compound 4 lay 2.7-fold (0.43 log units) below the measured number, and the stated range ends below it.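

On the core of compound 2, methoxy in place of amino gave a 1.4-fold higher number from compound 2 to compound 4 (0.16 log units; within the scatter) in this assay, so here the swap leaves the number within the usual scatter. The change therefore did not carry over from one core to the other, and the two steps differ by more than the scatter of such steps: the same change on two cores in this assay, a 2.2-fold lower number (0.34 log units; beyond the scatter) from compound 1 to compound 3 and a 1.4-fold higher number (0.16 log units; within the scatter) from compound 2 to compound 4, 3.1-fold (0.49 log units) apart, beyond the scatter of two such steps. Within these four compounds, the result on one core was a poor guide to the result on the other, but this does not show why the cores differ or how the change would behave on a further core.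

The compounds shown leave open how other groups at this place, such as an ethoxy group or a carboxylic acid, would behave on these two cores. They also leave open whether the difference between the cores would appear with those groups.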